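Swapping the aryl amine of compound 2 for a 4-ethylphenyl group

A few compounds are considered here, and "the series" means these few. Any claim that something is new, unique, unknown or untested is made for them only; others in the source may bear on it.

The three measured compounds share one core and differ only in the aromatic group carried on the amine nitrogen. Compound 1 `Cc1ccc(NC2=CC(=O)c3nc4n(c3C2=O)[C@H]2OC[C@@H](O)[C@H]2OC4)cc1C` bears a 3,4-dimethylphenyl group and in a functional assay on ECa-109 cells for inhibition, with ECa-109 cell line (Homo sapiens) as the target, read by sulforhodamine B assay (a lower number here means a stronger inhibitor, a higher number a weaker inhibitor), compound 1 gives 2820 nM. Compound 2 `O=C1C(Nc2cccc(Cl)c2)=CC(=O)c2c1nc1n2[C@H]2OC[C@@H](O)[C@H]2OC1` carries a 3-chlorophenyl group and in this assay compound 2 gives 3080 nM. Compound 3 `CCc1ccc(NC2=CC(=O)c3nc4n(c3C2=O)[C@H]2OC[C@@H](O)[C@H]2OC4)cc1` carries a 4-ethylphenyl group and in this assay compound 3 gives 3080 nM. Compound 2 sits level with compound 3 at the digits shown, and its gap to compound 1 is within the scatter; all three numbers lie close together.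

The step to the unmeasured compound 4 `CCc1ccc(NC2=CC(=O)c3c(nc4n3[C@H]3OC[C@@H](O)[C@H]3OC4)C2=O)cc1` is 4-ethylphenyl in place of 3-chlorophenyl on an amine nitrogen. Among the measured compounds shown here, the only measured step that bears on such an aryl exchange is a 1.1-fold higher number from compound 1 to compound 3 (0.04 log units; within the scatter), which also placed a 4-ethylphenyl group on the amine nitrogen and moved the number not at all beyond the scatter. On that basis compound 4 is expected to show a 1.0-fold lower number from compound 2 to compound 4 (0.01 log units; within the scatter), that is, no change beyond the scatter in this assay. Compound 4 is therefore estimated at 3000 nM, with a range from 1500 nM to 6000 nM.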

Compound 4, half-maximal inhibitory concentration: > 4000 nM
Compound 4 was reported as a limit; the forecaster's own chance of this, stated with the estimate: 5%; at least 1.3-fold (0.12 log units) between middle value and limit.
By their numbers in this assay, from the lowest: compounds 1, 2 and 3 (each within the scatter of the next). At a limit, above all of these: compound 4.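

Compound 4 is reported only as a limit, > 4000 nM, and not as a number. In this assay, placing 4-ethylphenyl in place of 3-chlorophenyl on the amine nitrogen gives an at least 1.2-fold higher number from compound 2 to compound 4 (0.11 log units; that floor lies within the scatter), so the exchange is not shown to move the result beyond the scatter, although a larger true step is not excluded. The earlier compounds all carried full numbers, whereas this change gives the first compound at this position whose inhibition runs out at the limit of the read-out: the limit of > 4000 nM in this assay, at which 1 of the 4 values shown sits.

On these data alone, how far compound 4 really lies from compound 2 stays unknown, so it remains open whether this exchange matters at all at the amine nitrogen. Also open, as far as these compounds go, is whether any loss would follow from the ethyl group itself or from its place on the ring, which a 3-ethylphenyl or a 4-chlorophenyl group on the same nitrogen would separate, and how an open-chain butylamino group would read in place of the aryl amines.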